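The source may report more compounds than this note shows. Statements on the series, on what has been measured and on what is new or still open speak of the compounds shown alone.

Measured compounds:
- compound 1 `COc1cccc2cc(C(=O)NCC(O)CO)c(=O)oc12`: 14%
- compound 2 `COc1cccc2cc(C(=O)N[C@@H](CO)C(=O)O)c(=O)oc12`: 12%

In an assay on CHO cells for displacement of a labelled ligand from adenosine receptor A1 (Homo sapiens), read by scintillation counting, with a stated time of 60 min, tested at 10 uM (on this read-out higher numbers stand for more inhibition at the one concentration tested (going by the name of the read-out) and lower numbers for less inhibition), compound 1 gives 14% and compound 2 gives 12%. Among the compounds with values here, on these two numbers compound 2 is not set apart from compound 1: the only measured step, a number 2 percentage points lower from compound 1 to compound 2 (within the scatter), lies within the scatter, so the two side chains on the amide-type nitrogen, 2,3-dihydroxypropyl and 1-carboxy-2-hydroxyethyl, read the same on the shared core of compound 2.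

Compound 3 `COc1cccc2cc(C(=O)NCCO)c(=O)oc12` is the next member. It differs from compound 2 as hydrogen in place of carboxy on a saturated chain carbon bound to an amide-type nitrogen and a saturated chain carbon; the same change, cut one bond further out, is 1-carboxy-2-hydroxyethyl to 2-hydroxyethyl on the amide-type nitrogen. Within the data shown here, the one step that bears on it, the exchange of side chains on that nitrogen from compound 1 to compound 2, was within the scatter, and no measured step removes a carboxy. With only that to go on, no step beyond the scatter is expected in this assay for compound 3, and the expected step of a number 1 percentage points higher from compound 2 to compound 3 (within the scatter) is taken as essentially flat. Compound 3 is therefore estimated at 13%, with a range from 2% to 26%.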

Compound 3, a percentage reported as inhibition, at one concentration (the size of the read-out at that concentration, not a potency): 12%
Compound 3: middle estimate off by 1 percentage points, on the high side, and the stated range covers the measured number.
By their numbers in this assay, from the lowest: compounds 2, 3 and 1 (each within the scatter of the next).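

In this assay, the first measured loss of carboxy, on a saturated chain carbon bound to an amide-type nitrogen and a saturated chain carbon, gives no change at the digits printed from compound 2 to compound 3 (within the scatter), so 1-carboxy-2-hydroxyethyl and 2-hydroxyethyl cannot be told apart on the shared core. The loss of hydroxymethyl, on a saturated chain carbon bound to an oxygen on a saturated carbon and a saturated chain carbon, gives a number 2 percentage points lower from compound 1 to compound 3 (within the scatter), so 2,3-dihydroxypropyl and 2-hydroxyethyl cannot be told apart either, and all three side chains on the amide-type nitrogen now read alike in this assay. No measurement at hand accounts for this sameness.

Open, from the compounds shown here alone, is whether a side chain ending in a primary amine, a longer alkyl chain without hydroxy, or a phenyl ring on the amide-type nitrogen would stand apart from these three in this assay. Also open, going by these compounds, is whether replacing the methoxy on the shared core with another group, such as ethoxy or chloro, would move the number, as all three compounds carry that same methoxy.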